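Compound 3: a lactam amide on the compound 2 scaffold

This account rests on a few compounds, and the source may have more. Where it says the series, first, only, none or still open, it means among the compounds named here.

Among the compounds with values here, in a physicochemical assay for solubility, measured as kinetic solubility, with a stated time of 1 h, at pH 7.4 (on this read-out higher numbers stand for higher solubility and lower numbers for lower solubility), compound 1 (`N#CCC(=O)Nc1nc(-c2ccc(Cl)c(Cl)c2)cs1`) gives 57000 nM and compound 2 (`CC(=O)NC1=NN(c2ccc(Cl)c(Cl)c2)CC1`) gives 31000 nM as the only two readings so far. Compound 2 therefore stands within the scatter of compound 1, and the two cannot be ranked. Compound 3 (`O=C1CCCC(C(=O)NC2=NN(c3ccc(Cl)c(Cl)c3)CC2)N1`) keeps the core of compound 2 and carries 6-oxopiperidin-2-yl in place of methyl on a carbonyl carbon. Within the data shown here, no measured step covers this change, so the expectation rests on compound 2 at 31000 nM alone. The estimated step of a 1.3-fold higher number from compound 2 to compound 3 (0.11 log units; within the scatter) is expected to stay within the scatter, with a slight upward lean and wide uncertainty. Compound 3 is estimated at 40000 nM with an expected range from 12000 nM to 110000 nM as a working estimate.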

Compound 3, solubility: 416000 nM
The estimate for compound 3 lay 10-fold (1.02 log units) below the measured number; measured number above the stated range.
By their numbers in this assay, from the lowest: compounds 2 and 1 (each within the scatter of the next); then compound 3.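

In this assay, 6-oxopiperidin-2-yl in place of methyl on a carbonyl carbon gives a 13-fold higher number from compound 2 to compound 3 (1.13 log units; beyond the scatter). Within the data shown here, this is the first step that can be read from a single change, and it shows that the read-out responds strongly at this place, on a carbonyl carbon whose other neighbours are: amide-type nitrogen. The data shown offer no measured explanation for the size of this step.

From the compounds shown here alone, it remains open which part of the entering group carries the step, and a cyclohexyl, a piperidin-2-yl or an open-chain amide on the same carbonyl carbon would help separate the ring from the lactam. Also open, going by these compounds, is whether 6-oxopiperidin-2-yl produces a similar step on the core of compound 1.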